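Ester chain replaces the carbonyl-linked piperidin-1-yl group

The source may report more compounds than this note shows. Statements on the series, on what has been measured and on what is new or still open speak of the compounds shown alone.

Of the compounds shown here, three on the shared core have been measured. In a functional assay for inhibition (on this read-out higher numbers stand for weaker inhibition and lower numbers for stronger inhibition), compound 3 (`CC(C)(C)c1cc(-c2cc(=O)c3ccc(OCC(=O)N4CCCCC4)cc3o2)cc(C(C)(C)C)c1O`) gives 3000 nM. Compound 1 (`CCOC(=O)COc1ccc2c(=O)cc(-c3cc(C(C)(C)C)c(O)c(C(C)(C)C)c3)oc2c1`) gives 3000 nM, the same number, and these two share the highest of the three values. Compound 2 (`CC(C)(C)c1cc(-c2cc(=O)c3ccc(OCCCS(=O)(=O)O)cc3o2)cc(C(C)(C)C)c1O`) gives 500 nM.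

The next structure is compound 4 (`CCOC(=O)CCCCOc1ccc2c(=O)cc(-c3cc(C(C)(C)C)c(O)c(C(C)(C)C)c3)oc2c1`). The change is 3-(ethoxycarbonyl)propyl in place of (piperidin-1-yl)carbonyl on a saturated chain carbon bound to an oxygen on an aromatic ring.

The closest measured evidence is the exchange of ethoxy and piperidin-1-yl on a carbonyl carbon, which shows no change at the digits printed from compound 1 to compound 3 (within the scatter). The two steps beyond the scatter, a 6.0-fold lower number from compound 1 to compound 2 (0.78 log units; beyond the scatter) and a 6.0-fold higher number from compound 2 to compound 3 (0.78 log units; beyond the scatter), both involve 2-sulfoethyl, which plays no part in this change. They are modest, and they offer no direct guide here. For the measured compounds named here, no measured pair isolates the added length of the chain, so that part of the change remains untested and the range is kept wide.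

No step beyond the scatter is expected in this assay, and the expected step is no change at the digits printed from compound 3 to compound 4 (within the scatter). Compound 4 is estimated at 3000 nM, with an expected range of 1000 nM to 8000 nM.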

Compound 4, half-maximal inhibitory concentration: 3000 nM
Compound 4: the middle estimate sits on the measured number at the digits printed; the measured number falls inside the stated range.
By their numbers in this assay, from the lowest: compound 2; then compounds 1, 3 and 4 (each within the scatter of the next).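

In this assay, for the compounds shown here, the ester chain can be compared at two lengths for the first time: 3-(ethoxycarbonyl)propyl in place of ethoxycarbonyl gives no change at the digits printed from compound 1 to compound 4 (within the scatter) and so adds no measurable shift at this position on a saturated chain carbon bound to an oxygen on an aromatic ring. Replacing (piperidin-1-yl)carbonyl with 3-(ethoxycarbonyl)propyl gives no change at the digits printed from compound 3 to compound 4 (within the scatter) in the same read-out, so the ring-bearing amide and the longer ester read alike here. Against compound 2 the longer ester gives a 6.0-fold higher number from compound 2 to compound 4 (0.78 log units; beyond the scatter). This places a third compound without the sulfo group at the level of compounds 1 and 3, leaving compound 2 the only one apart from that group, with no listed compound going against this.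

No supporting measurement accounts for any of these readings.

Still open, from the compounds shown here alone, is how a carboxylic acid or an amine in place of the ethoxycarbonyl group would read at this position, and whether the sulfo group keeps its lower number on a longer chain.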